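This account rests on a few compounds, and the source may have more. Where it says the series, first, only, none or still open, it means among the compounds named here.

Within the data shown here, compound 1, with the structure `CCCCCCCCCCCCNc1nc(=O)c2c(ncn2[C@H]2C[C@H](O)[C@@H](CO)O2)c(=O)[nH]1`, is the one compound here with a measured number: in an assay on isolated protein for inhibition of ATP-dependent RNA helicase SUPV3L1, mitochondrial (Homo sapiens) (a lower number here means a stronger inhibitor, a higher number a weaker inhibitor), compound 1 gives 3 ug/mL. Compound 2, with the structure `CCCCCCCCCCCCCCCCNc1nc(=O)c2ncn([C@@H]3O[C@H](CO)[C@@H](O)[C@H]3O)c2c(=O)[nH]1`, reaches only a limit of the assay, > 500 ug/mL. Compound 3, with the structure `CCCCCCCCCCNc1nc(=O)c2ncn([C@@H]3O[C@H](CO)[C@@H](O)[C@H]3O)c2c(=O)[nH]1`, likewise reaches only a limit, > 500 ug/mL. The step that the two limits leave unreadable from compound 2 to compound 3 therefore cannot be read, and the limit of > 500 ug/mL in this assay, at which 2 of the 3 values shown sit, is where both of those values sit.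

Compound 4, with the structure `CCCCCCCCCCCCNc1nc(=O)c2c(ncn2[C@@H]2C[C@H](O)[C@@H](CO)O2)c(=O)[nH]1`, is not yet measured. It differs from compound 1 as follows: the two compounds have the same atoms and bonds and differ only in configuration as drawn: 1 of 3 stereo elements differ; a stereocentre at a saturated ring carbon is drawn R in compound 1 and S in compound 4. Among the measured compounds shown here, none of the measured steps touches a change of configuration, so no measured step bears directly on this one, and the only guide is that compound 1 itself gives 3 ug/mL. With the same atoms and bonds and only one stereocentre drawn differently, the expected step of a 2.0-fold higher number from compound 1 to compound 4 (0.30 log units; within the scatter) is modest, with some chance of weaker inhibition rather than stronger. Compound 4 is therefore expected to give about 6 ug/mL, most likely between 1.5 ug/mL and 40 ug/mL.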

Compound 4, half-maximal inhibitory concentration: 250 ug/mL
Compound 4: the middle estimate sits 42-fold (1.62 log units) below what was measured; the whole stated range lies below it.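

In this assay, changing one stereocentre at a saturated ring carbon, from R in compound 1 to S in compound 4, gives an 83-fold higher number from compound 1 to compound 4 (1.92 log units; beyond the scatter). Among these compounds, none of the earlier steps involved configuration, so this is the first evidence that the drawn arrangement at this ring carbon strongly affects the number. The step can be assigned to this single stereocentre, because no other change separates the pair: the fact that compounds 1 and 4 differ only in the configuration as drawn.

The compounds shown do not reveal whether changing either of the other two stereo elements would give a step of similar size. They also leave open whether an amine or a carboxylic acid on the chain of compound 1 would keep its number or change it.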